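A few compounds are considered here, and "the series" means these few. Any claim that something is new, unique, unknown or untested is made for them only; others in the source may bear on it.

Working notes on the aryl sulfonate series, taken at the step from compound 2 to compound 3.

Compound 1 `CCCC(=O)Nc1ccc(S(=O)(=O)Oc2ccccc2I)cc1` and compound 2 `CCCCCC(=O)Nc1ccc(S(=O)(=O)Oc2ccccc2I)cc1` share the same core and differ only in the acyl chain on the amide nitrogen. In a functional assay on HT-1080 cells (Homo sapiens) for antiproliferative activity, read by sulforhodamine B assay, with a stated time of 48 h (a lower number here means a stronger inhibitor, a higher number a weaker inhibitor), compound 1 gives 2000 nM, and in the same assay compound 2 gives 9600 nM. Within the data shown here, the one measured step, a 4.8-fold higher number from compound 1 to compound 2 (0.68 log units; beyond the scatter), therefore goes against chain lengthening. Among the measured compounds shown here, compound 2 stands at the higher of the two numbers so far.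

Compound 3 `CC(C)C(=O)Nc1ccc(S(=O)(=O)Oc2ccccc2I)cc1` carries the change (isopropyl in place of pentyl on a carbonyl carbon). This removes the pentyl chain in favour of a branched three-carbon group, which by carbon count matches the propyl chain of compound 1 rather than the pentyl chain of compound 2. For the measured compounds named here, the step from compound 1 to compound 2 is the only measured step that bears on this change; it was modest but beyond the scatter, and it ran in the direction of the larger group giving the larger number. The move to compound 3 runs the other way in chain size, so the expected step in this assay is a return toward the number of compound 1, roughly reversing the measured step, as an expectation only. Compound 3 is accordingly estimated at 2500 nM, with a range of 900 nM to 7000 nM, which is expected to mean a step of a 3.8-fold lower number from compound 2 to compound 3 (0.58 log units; beyond the scatter) from compound 2 to compound 3.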

Compound 3, half-maximal inhibitory concentration: 3300 nM
For compound 3 the middle estimate is 1.3-fold (0.12 log units) below the measured one; the range from low to high includes it.
By their numbers in this assay, from the lowest: compounds 1 and 3 (each within the scatter of the next); then compound 2.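

In this assay the exchange of pentyl for isopropyl on a carbonyl carbon gives a 2.9-fold lower number from compound 2 to compound 3 (0.46 log units; beyond the scatter) and so stands beyond the scatter, which places pentyl apart from the smaller group a second time, now against a branched partner as well as a straight one. Branching itself can be read for the first time: isopropyl in place of propyl gives a 1.7-fold higher number from compound 1 to compound 3 (0.22 log units; within the scatter) and this leaves the two groups indistinguishable at this position, so among the three compounds only pentyl separates from the others, and compound 1 and compound 3 share one level. Nothing at hand gives a reason for either step.

As far as these compounds go, with only propyl, isopropyl and pentyl at this position, the shape of the chain-length trend remains unknown, including where butyl would fall and whether a methyl or a hexyl group would continue the same direction. Also open, from the compounds shown here alone, is how a cyclopropyl ring, or a chain ending in an amine or a carboxylic acid, would read in this assay against these simple alkyl groups.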